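Amide variation on the shared core: acid in place of allyl

The compounds below may be only part of what the source reports. "The series", "measured", "known", "first", "only" and "open" are said of these compounds alone.

Compound 2 `C=CCN(C)C(=O)c1ccc(C(CC)(CC)c2ccc(OCCC(O)(CC)CC)c(C)c2)n1CC` sits in a functional assay on Caco-2 cells (Homo sapiens) for antiproliferative activity, read by MTT assay, with a stated time of 48 h (on this read-out lower numbers stand for stronger inhibition and higher numbers for weaker inhibition), at a limit of the assay, > 50000 nM, not at a number. Compound 3 `CCn1c(C(=O)Nc2cccc(C(F)(F)F)c2)ccc1C(CC)(CC)c1ccc(OCCC(O)(CC)CC)c(C)c1` also sits at a limit, > 50000 nM. For the measured compounds named here, compound 1 `CCn1c(C(=O)NCCCN(C)C)ccc1C(CC)(CC)c1ccc(OCCC(O)(CC)CC)c(C)c1` is the only member giving a number, 490 nM; two of the three values stand at the limit of > 50000 nM in this assay, at which 2 of the 3 values shown sit.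

Compound 4 `CCC(C)C(NC(=O)c1ccc(C(CC)(CC)c2ccc(OCCC(O)(CC)CC)c(C)c2)n1CC)C(=O)O` differs from compound 2 in (1-carboxy-2-methylbutyl)amino in place of allyl(methyl)amino on a carbonyl carbon. The steps touching this carbonyl carbon are an at least 100-fold higher number from compound 1 to compound 2 (2.00 log units; beyond the scatter) and an at least 100-fold higher number from compound 1 to compound 3 (2.00 log units; beyond the scatter), both large, while a step that the two limits leave unreadable from compound 2 to compound 3 cannot be read between two limits. Compound 4 lacks the (3-(dimethylamino)propyl)amino group that compound 1 carries at 490 nM. For compound 4 a further limit is expected, and a step that the limit leaves unreadable from compound 2 to compound 4 is then not expected to be readable. Compound 4 is estimated at 60000 nM, between 15000 nM and 200000 nM.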

Compound 4, half-maximal inhibitory concentration: 20000 nM
Estimate against measurement, compound 4: 3.0-fold (0.48 log units) above; the measured number falls inside the stated range.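

In this assay a carbonyl substituent other than (3-(dimethylamino)propyl)amino can now give a number instead of a limit: (1-carboxy-2-methylbutyl)amino gives an at least 2.5-fold lower number from compound 2 to compound 4 (0.39 log units; beyond the scatter) and an at least 2.5-fold lower number from compound 3 to compound 4 (0.39 log units; beyond the scatter) in this series. Both steps start from limits: the limit of > 50000 nM in this assay, at which 2 of the 4 values shown sit.
The new group still falls well short of the dimethylamino chain, with a 41-fold higher number from compound 1 to compound 4 (1.61 log units; beyond the scatter) on that comparison.

Open, from the compounds shown here alone, is whether the gain belongs to the carboxylic acid or to the branched chain, which a methyl ester would separate. Also open, going by these compounds, is how a longer chain ending in the dimethylamine would read.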